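Swapping the fluorophenyl group on a nucleoside-like scaffold

This account rests on a few compounds, and the source may have more. Where it says the series, first, only, none or still open, it means among the compounds named here.

Three related compounds share one core and differ only in the aromatic group attached to a saturated chain carbon bound to a nitrogen on an aromatic ring. Compound 1 `OC[C@H]1O[C@@H](n2cnc3c(NCc4cccc(F)c4)ncnc32)[C@H](O)[C@@H]1O` carries a 3-fluorophenyl there; in an ADME assay on NIH3T3 cells (Mus musculus) for cytotoxicity, with a stated time of 72 h (a lower number here means a stronger inhibitor, a higher number a weaker inhibitor), compound 1 gives 84000 nM, the lowest of the two plain numbers recorded, with compound 3 `COc1ccccc1CNc1ncnc2c1ncn2[C@@H]1O[C@H](CO)[C@@H](O)[C@H]1O`, which carries a 2-methoxyphenyl, giving 140000 nM. Compound 2 `OC[C@H]1O[C@@H](n2cnc3c(NCc4ccc(Br)cc4)ncnc32)[C@H](O)[C@@H]1O`, with a 4-bromophenyl, reaches only a limit of the assay at > 166000 nM.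

Compound 4 `OC[C@H]1O[C@@H](n2cnc3c(NCc4ccc(F)cc4Cl)ncnc32)[C@H](O)[C@@H]1O` has not yet been measured. It differs from compound 1 in one place: 2-chloro-4-fluorophenyl in place of 3-fluorophenyl on a saturated chain carbon bound to a nitrogen on an aromatic ring.

Two measured steps speak to this change. Replacing the 3-fluorophenyl gave an at least 1.9-fold higher number from compound 1 to compound 2 (0.29 log units; that floor lies within the scatter) and a 1.7-fold higher number from compound 1 to compound 3 (0.22 log units; within the scatter); both lie within the usual scatter of the assay. Going by these compounds, the closest comparison, the move to a 4-bromophenyl, ended at a limit (the limit of > 166000 nM in this assay, at which 1 of the 3 values shown sits), so the true size of that step is unknown.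

Taken together, the change to a 2-chloro-4-fluorophenyl is expected to shift this assay little, if at all, with the number more likely to rise than to fall. Compound 4 is therefore estimated at 110000 nM, within a range of 50000 nM to 250000 nM, which corresponds to an expected step of a 1.3-fold higher number from compound 1 to compound 4 (0.12 log units; within the scatter).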

Compound 4, half-maximal inhibitory concentration: > 166000 nM
Compound 4: no number, only a limit (the forecaster's own chance of this, stated with the estimate: 30%); at least 1.5-fold (0.17 log units) between middle value and limit.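

Compound 4, like compound 2, gives no number in this assay, only a limit, so two different aromatic groups at this place now end at the same limit: the limit of > 166000 nM in this assay, at which 2 of the 4 values shown sit.

Replacing the 3-fluorophenyl with the 2-chloro-4-fluorophenyl gives an at least 1.9-fold higher number from compound 1 to compound 4 (0.29 log units; that floor lies within the scatter), and replacing the 2-methoxyphenyl with the same group gives an at least 1.1-fold higher number from compound 3 to compound 4 (0.07 log units; that floor lies within the scatter). These floors show that adding a chlorine and moving the fluorine produced no number lower than the earlier ones, yet neither step can be called a real change, and the step linking compound 2 and compound 4 cannot be read, with a limit on each side.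

Going by these compounds, how far the true values of compound 2 and compound 4 lie beyond the limit remains unknown, so these two groups cannot be ranked against each other. The compounds shown also leave open what an amine, a carboxylic acid or a longer chain would do at this place on the shared core, since every group here is a substituted phenyl on the same short link.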